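Swapping a thiophene for an allyl chain on a triazene

This account rests on a few compounds, and the source may have more. Where it says the series, first, only, none or still open, it means among the compounds named here.

Of the compounds shown here, two have been measured so far in a functional assay on L1210 cells (Mus musculus) for antiproliferative activity; on this read-out lower numbers stand for lower potency and higher numbers for higher potency (the scale is a negative logarithm). Compound 1, with the structure `CN(/N=N/c1ccc(C(N)=O)cc1)c1cccs1`, gives 2.9 in this assay. Compound 2, with the structure `CN(C)/N=N/c1ccc(S(=O)(=O)Nc2ncccn2)cc1`, gives 3.74 in this assay. On these two numbers compound 1 stands lowest, and its nearest neighbour is compound 2, whose value lies higher by a margin beyond the usual scatter.

The step under consideration leads from compound 1 to compound 3, whose structure is `C=CCN(C)/N=N/c1ccc(C(N)=O)cc1`. The change is allyl in place of thiophen-2-yl on an amine nitrogen. Among the measured compounds shown here, no pair of measured compounds differing in a single place is available, so the size of this step cannot be read off directly from the data. For the measured compounds named here, with only two measured values, the direction is a matter of expectation rather than record.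

Given that compound 2 gives 3.74 while compound 1 gives 2.9, an upward move appears plausible, though the uncertainty is wide. Compound 3 is therefore expected to reach about 3.6 in this assay, within a range from 3 to 4.2. The step of a number 0.70 log units higher from compound 1 to compound 3 (beyond the scatter) is the estimated change this implies.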

Compound 3, logarithm of the reciprocal of the active concentration, log(1/C): 3.38
The estimate for compound 3 lay 0.22 log units above the measured number, within the range that was stated.
By their numbers in this assay, from the lowest: compound 1; then compound 3; then compound 2.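

In this assay, among the compounds shown here, this pair gives the first direct reading of what the amine nitrogen tolerates, because the two compounds differ in that one place only: putting allyl in place of thiophen-2-yl gives a number 0.48 log units higher from compound 1 to compound 3 (beyond the scatter). The five-membered aromatic ring, with its sulfur, is therefore not required for activity in this pair, and an open chain with fewer heavy atoms, no ring and one double bond does measurably better on the same core. Nothing measured here accounts for the rise, so the result records the size and direction of this one change without explaining it.

One pair cannot separate the loss of the ring, the smaller group and the presence of the double bond, and it cannot show whether the rise would carry over to other cores. A saturated propyl chain on the same nitrogen would pose the question about the double bond directly, and a furan ring in that place would ask whether the sulfur-containing ring itself matters or any five-membered aromatic ring behaves alike.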